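Removing bromo from compound 2 in the shared core

The source may hold more compounds than are shown below. What is called first, only, known or untested is meant among the compounds shown, and "the series" means these compounds.

Working notes on the series. Two compounds stand measured in a functional assay on RAW264.7 cells (Mus musculus) for inhibition, read by ELISA, with stated times of 2 h and 22 h; a higher number here means a weaker inhibitor, a lower number a stronger inhibitor. Compound 1 `CCCn1c(-c2ccc(OCCCN(C)C)cc2)nc2ccc(N3CCN(C)CC3)nc21` gives 3280 nM there. Compound 2 `CCCn1c(-c2c[nH]c3ccc(Br)cc23)nc2ccc(N3CCN(C)CC3)nc21` gives 1210 nM in this assay, the lower of the two numbers, and the gap to compound 1 lies beyond the scatter. Among the compounds with values here, no pair of measured compounds differs in a single place, so nothing shows how a one-point change moves the numbers.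

Compound 3 `CCCn1c(-c2c[nH]c3ccccc23)nc2ccc(N3CCN(C)CC3)nc21` is set against compound 2 by the change (hydrogen in place of bromo on an aromatic carbon). Bromo leaves and hydrogen enters on an aromatic carbon of a six-membered aromatic ring of carbon only, part of a fused system of two rings.

Within the data shown here, with no measured step to rest on, the expected step in this assay is a 1.8-fold higher number from compound 2 to compound 3 (0.26 log units; within the scatter), a modest weakening that may well sit within the scatter. Compound 3 is therefore estimated at 2200 nM, with a range from 800 nM to 6500 nM.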

Compound 3, half-maximal inhibitory concentration: 4300 nM
Estimate against measurement, compound 3: 2.0-fold (0.29 log units) below; measured number inside the range.
By their numbers in this assay, from the lowest: compound 2; then compounds 1 and 3 (each within the scatter of the next).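

Within the data shown here, this is the first one-point step: in this assay, hydrogen in place of bromo on an aromatic carbon gives a 3.6-fold higher number from compound 2 to compound 3 (0.55 log units; beyond the scatter). The step lies beyond the scatter, so what sits at this place, meta to a fused ring and para to a fused ring, does move the number, and bromo goes with the stronger inhibition of the pair. Nothing at hand gives a reason for this step.

From the compounds shown here alone, only bromo and hydrogen are compared at this place, so it stays open whether chloro, fluoro, methyl or methoxy there would match bromo or fall back towards hydrogen. Also open, going by these compounds, is whether the same change on another aromatic carbon of that ring would move the number to a similar extent.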